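The source may report more compounds than this note shows. Statements on the series, on what has been measured and on what is new or still open speak of the compounds shown alone.

Working notes on the series.

Compound 1 `CC(C)C(c1ncco1)c1ccc(-c2ccc3cccc(F)c3c2)[nH]c1=O` is the reference point here. In an assay on CHO cells for displacement of a labelled ligand from prostaglandin E2 receptor EP3 subtype (Homo sapiens), read by radioligand binding (on this read-out lower numbers stand for stronger inhibition and higher numbers for weaker inhibition), compound 1 gives 24 nM, the lowest of the three numbers, though its gaps to the other two fall within the usual scatter. Compound 2 `CCn1ncc2c(F)cc(-c3ccc(C(CC)(CC)c4nnc(C)[nH]4)c(=O)[nH]3)cc21` gives 34 nM and compound 3 `CCn1ncc2c(F)cc(-c3ccc(C(CC)(CC)c4ncn(C)n4)c(=O)[nH]3)cc21` gives 39 nM in this assay, so the three sit together and no order among them can be read.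

Among the measured compounds shown here, the one measured step, a 1.1-fold higher number from compound 2 to compound 3 (0.06 log units; within the scatter), swaps one triazole for another and stays within the scatter; it says only that changing the small heterocycle on the branching carbon of compound 2 is tolerated there.

Compound 4 `CC(C)NC(=O)CC(c1ccc(-c2ccc3cccc(F)c3c2)[nH]c1=O)C(C)C` differs from compound 1 by (isopropylcarbamoyl)methyl in place of 1,3-oxazol-2-yl on a saturated chain carbon bound to an aromatic carbon and a saturated chain carbon. For the measured compounds named here, no measured pair trades a ring for an open chain of this kind, so the step from compound 2 to compound 3 bears on it only loosely, and the expectation rests mainly on that tolerance. A modest weakening, a 2.9-fold higher number from compound 1 to compound 4 (0.46 log units; beyond the scatter), is expected, with a wide range. Compound 4 is therefore estimated at 70 nM, between 18 nM and 300 nM.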

Compound 4, inhibition constant: 5.8 nM
Estimate against measurement, compound 4: 12-fold (1.08 log units) above, and the stated range ends above it.
By their numbers in this assay, from the lowest: compound 4; then compounds 1, 2 and 3 (each within the scatter of the next).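

In this assay, (isopropylcarbamoyl)methyl in place of 1,3-oxazol-2-yl gives a 4.1-fold lower number from compound 1 to compound 4 (0.62 log units; beyond the scatter). On a saturated chain carbon bound to an aromatic carbon and a saturated chain carbon, an aromatic ring is therefore not required, and an open chain gives a lower number beyond the scatter, whereas the earlier triazole swap, on another core, only exchanged one ring for another within the scatter. Nothing available bears on why the number falls.

Going by these compounds, the step replaces the whole group at once, so it remains open which part of the chain goes with the lower number: the amide hydrogen, the carbonyl or the isopropyl end. Also open, on these data alone, is whether a carboxylic acid, a primary amide or a longer chain on the same carbon would keep that number, and whether (isopropylcarbamoyl)methyl would do the same on the core of compound 2.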